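The source may hold more compounds than are shown below. What is called first, only, known or untested is meant among the compounds shown, and "the series" means these compounds.

Measured compounds in this series:

- Compound 1 `COc1cc(-c2ncnn2-c2ccc(F)cc2)cc(OC)c1OC`: in a functional assay on HeLa cells (Homo sapiens) for antiproliferative activity, read by MTT assay, with a stated time of 72 h (a higher number here means a weaker inhibitor, a lower number a stronger inhibitor), compound 1 gives > 10000 nM, which is a limit of the assay and not a number.
- Compound 2 `COc1cc(-c2ncnn2-c2ccc([N+](=O)[O-])cc2)cc(OC)c1OC`: in this assay compound 2 gives > 10000 nM, again a limit of the assay rather than a number.

Compound 2 therefore stands at the top of what this assay reports; the evidence on the measured values is the limit of > 10000 nM in this assay, at which 2 of the 2 values shown sit. For the measured compounds named here, the one measured step, a step that the two limits leave unreadable from compound 1 to compound 2, cannot be read as a size, so it gives no number to carry forward.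

Compound 3 `COc1cc(-c2ncnn2-c2ccc(N)cc2)cc(OC)c1OC` differs from compound 2 by amino in place of nitro on an aromatic carbon. Going by the values given here, no measured step in this assay bears on this change with a readable size. Compound 2 sits at a limit, and compound 3 is expected to sit near the same region, with a real chance that the assay again returns only a limit. The estimate for compound 3 in this assay is 15000 nM, with an expected range from 3000 nM to 60000 nM. The step that the limit leaves unreadable from compound 2 to compound 3 is thus expected to be small, not readable beyond the scatter.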

Compound 3, half-maximal inhibitory concentration: > 10000 nM
Compound 3 gave a limit, no number (the forecaster's own chance of this, stated with the estimate: 70%); the middle value does not contradict the limit.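

Compound 1, compound 2 and compound 3 all return only a limit of the assay in this assay, so no step among them can be read: the limit of > 10000 nM in this assay, at which 3 of the 3 values shown sit.

The compounds shown leave open whether any change at this aromatic carbon would give a readable value.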